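A few compounds are considered here, and "the series" means these few. Any claim that something is new, unique, unknown or untested is made for them only; others in the source may bear on it.

In a functional assay for inhibition, with Homo sapiens as the target (on this read-out lower numbers stand for stronger inhibition and higher numbers for weaker inhibition), the three measured compounds stand as follows:

Compound 1, `CCc1ccc(Nc2nccc(-c3ccncc3)n2)cc1`: 7700 nM
Compound 2, `CC1CCN(c2ccc(Nc3nccc(-c4ccco4)n3)cc2)CC1`: 1800 nM
Compound 3, `CN(C)c1ccc(Nc2nccc(-c3ccncc3)n2)cc1`: 3700 nM

Compound 3 holds the second highest of the three numbers. Among the compounds with values here, the only measured step that reaches it is a 2.1-fold lower number from compound 1 to compound 3 (0.32 log units; beyond the scatter), a modest change that follows from putting dimethylamino in place of ethyl.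

Compound 4, `CC1CCN(c2ccc(Nc3nccc(-c4ccncc4)n3)cc2)CC1`, has not yet been measured in this assay. It differs from compound 3 in one place: 4-methylpiperidin-1-yl in place of dimethylamino on an aromatic carbon. Within the data shown here, no measured step shows this exact exchange on this core. The closest hint comes from compound 2, which carries the same 4-methylpiperidin-1-yl group but on a different core, and its value sits lower than that of compound 3 by an amount beyond the scatter. Since the measured step of a 2.1-fold lower number from compound 1 to compound 3 (0.32 log units; beyond the scatter) shows that a change at this position can shift the read-out by a modest amount, and compound 2 points in the lower direction, a modest move to a lower number is the reasonable expectation here, though the difference in core leaves that uncertain.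

The estimated value for compound 4 in this assay is therefore 2200 nM, within a range from 900 nM to 5500 nM, corresponding to an expected step of a 1.7-fold lower number from compound 3 to compound 4 (0.23 log units; within the scatter).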

Compound 4, half-maximal inhibitory concentration: 600 nM
The estimate for compound 4 lay 3.7-fold (0.56 log units) above the measured number; measured number below the stated range.
By their numbers in this assay, from the lowest: compound 4; then compound 2; then compound 3; then compound 1.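

In this assay, the exchange on the shared core of dimethylamino for 4-methylpiperidin-1-yl gives the clearest comparison so far (a 6.2-fold lower number from compound 3 to compound 4 (0.79 log units; beyond the scatter)), and it shows that this position can do more than the modest shift seen earlier (a 2.1-fold lower number from compound 1 to compound 3 (0.32 log units; beyond the scatter)). Measured against the small ethyl group, the same ring, which brings more heavy atoms and a six-membered non-aromatic ring, produces a large change (a 13-fold lower number from compound 1 to compound 4 (1.11 log units; beyond the scatter)), so among the three groups compared on this core the order of the numbers runs from ethyl, the highest, through dimethylamino to 4-methylpiperidin-1-yl, the lowest. The other end of the molecule counts as well, since with 4-methylpiperidin-1-yl held fixed, pyridin-4-yl in place of furan-2-yl also lowers the number (a 3.0-fold lower number from compound 2 to compound 4 (0.48 log units; beyond the scatter)).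

Nothing in the data shown accounts for why these exchanges move the read-out as they do. The compounds shown leave open whether the ring itself or its methyl group carries the change, which piperidin-1-yl without the methyl, morpholin-4-yl or an open chain such as diethylamino at this position could help to separate.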